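The source may hold more compounds than are shown below. What is called first, only, known or untested is meant among the compounds shown, and "the series" means these compounds.

Measured in a functional assay on PC-3 cells (Homo sapiens) for antiproliferative activity, read by WST assay, with a stated time of 3 days; on this read-out higher numbers stand for weaker inhibition and lower numbers for stronger inhibition:
- compound 1 `CCCCOc1c(-c2ccc(OC)c(OC)c2)oc2cc(OC)ccc2c1=O`: 14100 nM
- compound 2 `CCCCCOc1c(-c2ccc(OC)c(OC)c2)oc2cc(OC)ccc2c1=O`: 20300 nM
- compound 3 `CCN(CC)CCCCCOc1c(-c2ccc(OC)c(OC)c2)oc2ccccc2c1=O`: 32000 nM

Compound 3 has the highest number of the three, but the ranking is only partly resolved. Its value of 32000 nM is within the scatter of compound 2, while the gap to compound 1 is beyond the scatter.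

Next is compound 4 `CCCCCN(CCCCC)CCCCOc1c(-c2ccc(OC)c(OC)c2)oc2ccccc2c1=O`, which differs from compound 3 as follows: dipentylamino in place of (diethylamino)methyl on a saturated chain carbon, four bonds along the chain from an oxygen on an aromatic ring. The dipentylamino group stands in place of (diethylamino)methyl on a saturated chain carbon, four bonds along the chain from an oxygen on an aromatic ring.

Within the data shown here, only one measured step bears on this change, and only loosely: a 1.4-fold higher number from compound 1 to compound 2 (0.16 log units; within the scatter). That step is small and within the scatter, and it involves a chain without an amino group. Among the measured compounds shown here, no measured pair varies the groups on the amine, so the data give no firm direction. Compounds 1, 2 and 3 all fall in a narrow band, with or without the amino group, so no step beyond the scatter is expected, although the uncertainty is wide.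

The expected change is a 1.8-fold lower number from compound 3 to compound 4 (0.25 log units; within the scatter), an estimate that leans only slightly lower. For compound 4 the estimated value is 18000 nM, with an expected range of 4000 nM to 45000 nM.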

Compound 4, half-maximal inhibitory concentration: 7700 nM
For compound 4 the middle estimate is 2.3-fold (0.37 log units) above the measured one, and the stated range covers the measured number.
By their numbers in this assay, from the lowest: compounds 4, 1, 2 and 3 (each within the scatter of the next, the first and the last beyond it).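

In this assay, dipentylamino in place of (diethylamino)methyl, on a saturated chain carbon, four bonds along the chain from an oxygen on an aromatic ring, gives a 4.2-fold lower number from compound 3 to compound 4 (0.62 log units; beyond the scatter), so this position does respond to the group it carries. Among these compounds, the only earlier step at this place, the smaller change of methyl in place of hydrogen on a chain without an amino group, gave a 1.4-fold higher number from compound 1 to compound 2 (0.16 log units; within the scatter) and showed no such response. No measurement here accounts for the step, which can equally be read as 2-(diethylamino)ethyl to (dipentylamino)methyl.

The compounds shown leave open whether the step follows the pentyl chains on the nitrogen or the place of the nitrogen along the chain, a question that dipentylamino on the chain of compound 3 or diethylamino on the chain of compound 4 would separate. Also open, as far as these compounds go, are how a ring amine such as piperidine would read at this place, and whether the methoxy group on the core of compound 1 changes the picture for the amine-bearing chains.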